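The source may hold more compounds than are shown below. What is called first, only, known or untested is meant among the compounds shown, and "the series" means these compounds.

Of the compounds shown here, three have so far been read in a functional assay on HepG2 cells (Homo sapiens) for cytotoxicity, read by MTT assay, with a stated time of 72 h; a lower number here means a stronger inhibitor, a higher number a weaker inhibitor. Compound 1 `CC[S+]([O-])CCCCN=C=S` gives 5350 nM, compound 2 `COc1ccc(C[S+]([O-])CCCCN=C=S)cc1` gives 4620 nM, and compound 3 `[O-][S+](CCCCN=C=S)CCc1ccccc1` gives 6970 nM. Compound 1 therefore stands within the scatter of both other compounds, and these three numbers form a single level with no order that can be trusted.

Compound 4 `[O-][S+](CCCCN=C=S)Cc1cccs1` has not yet been measured. It departs from compound 1 through thiophen-2-yl in place of methyl on a saturated chain carbon bound to a sulfur. For the measured compounds named here, no pair of measured compounds differs in one place only, so no direct step is available to guide the expectation, and the evidence is indirect. Compound 2, at 4620 nM, and compound 3, at 6970 nM, also differ from compound 1 in the group carried on the sulfur, yet both values remain within the scatter of compound 1. On that basis, no change beyond the scatter is expected in this assay for this replacement. The estimated result is a 1.1-fold lower number from compound 1 to compound 4 (0.03 log units; within the scatter), a step that would stay within the scatter. Compound 4 is expected to give about 5000 nM, with an estimated range from 2500 nM to 10000 nM.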

Compound 4, half-maximal inhibitory concentration: 3820 nM
Compound 4: the middle estimate sits 1.3-fold (0.12 log units) above what was measured; the measured number falls inside the stated range.
By their numbers in this assay, from the lowest: compounds 4, 2, 1 and 3 (each within the scatter of the next).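

In this assay, for the compounds shown here, a 1.4-fold lower number from compound 1 to compound 4 (0.15 log units; within the scatter) gives the first direct reading of a single change at this place, on a saturated chain carbon bound to a sulfur. It shows that thiophen-2-yl, with its five-membered aromatic ring and its hydrogen-bond acceptor, can stand in place of methyl without the difference passing beyond the scatter, so this one comparison gives no sign that the assay separates the two groups. Nothing among the data shown offers an explanation of this reading, which therefore stands as a bare comparison of two compounds.

The compounds shown leave open whether any group at this place can move the number beyond the scatter in this assay, for instance an amine or a carboxylic acid in place of thiophen-2-yl. Going by these compounds alone, they also leave open whether a longer chain, in place of the one shared by compound 1 and compound 4, would separate these compounds, and whether the level seen so far holds once that shared chain is altered.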